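Solubility notes: aryl exchange on the shared core

The source may hold more compounds than are shown below. What is called first, only, known or untested is meant among the compounds shown, and "the series" means these compounds.

Compound 1, `CNC(=O)c1cc(C(=O)N[C@H]2CC[C@H](O)CC2)c([C@@H](C)c2ccc(Cl)cc2)o1`, in a physicochemical assay for solubility, measured as kinetic solubility (a lower number here means a less soluble compound, a higher number a more soluble compound), gives >= 118 ug/mL, a limit of the assay.
Compound 2, `CNC(=O)c1cc(C(=O)N[C@H]2CC[C@H](O)CC2)c([C@@H](C)c2ccccc2Cl)o1`, in this assay gives >= 242 ug/mL, also a limit.
Compound 3, `CNC(=O)c1cc(C(=O)N[C@H]2[C@@H]3C[C@@H](O)C[C@@H]32)n([C@@H](C)c2cccc(Cl)c2)n1`, in this assay gives 175 ug/mL.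

Compound 2 stands only at a limit in this assay; of the other values shown, that of compound 1 is also a limit, and only compound 3 gives a number. Compound 4, `CNC(=O)c1cc(C(=O)N[C@H]2CC[C@H](O)CC2)c([C@@H](C)c2cccc(OC)c2)o1`, is not yet measured. It differs from compound 2 by 3-methoxyphenyl in place of 2-chlorophenyl on a saturated chain carbon bound to an aromatic carbon and a saturated chain carbon. Among the measured compounds shown here, the single measured step at this position, a step that the two limits leave unreadable from compound 1 to compound 2, cannot be read because both ends sit at limits (the limit of >= 118 ug/mL in this assay, at which 1 of the 3 values shown sits, (the limit of >= 242 ug/mL in this assay, at which 1 of the 3 values shown sits)). For the measured compounds named here, no measured step therefore sets a size or direction for the new change, and with all three values high no step beyond the scatter is expected. Compound 4 is expected at 200 ug/mL, within 80 ug/mL to 400 ug/mL. The expected step is then an at least 1.2-fold lower number from compound 2 to compound 4 (0.08 log units; that floor lies within the scatter).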

Compound 4, solubility: >= 113 ug/mL
Compound 4: a limit, no number; the forecaster's own chance of this, stated with the estimate: 50%; the middle value lies beyond the limit too.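

Compound 1, compound 2 and compound 4 all stand at limits in this assay, and the steps among them cannot be read. The compounds shown leave open whether 4-chlorophenyl, 2-chlorophenyl and 3-methoxyphenyl differ at all in this read-out.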